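Ethyl to But-1-yn-1-yl on a Sugar Ring Carbon

This account rests on a few compounds, and the source may have more. Where it says the series, first, only, none or still open, it means among the compounds named here.

Measured so far:
compound 1, `C=C[C@@]1(O)[C@@H](CO)O[C@@H](n2ccc(=O)[nH]c2=O)[C@@H]1O`, in a functional assay on Sarcoma-180 cells (Mus musculus) for cytotoxicity (a lower number here means a stronger inhibitor, a higher number a weaker inhibitor), compound 1 gives > 30000 nM
compound 2, `CC[C@@]1(O)[C@@H](CO)O[C@@H](n2ccc(N)nc2=O)[C@@H]1O`, in this assay compound 2 gives > 30000 nM

Neither of these readings is a number. For compound 1 the value is a limit of the assay. For compound 2 the value is likewise a limit of the assay. Compound 2 therefore stands at the limit of > 30000 nM in this assay, at which 2 of the 2 values shown sit, and nothing in the two values separates it from compound 1. For the measured compounds named here, no step between measured compounds can be drawn from them.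

The unmeasured compound 3, `CCC#C[C@@]1(O)[C@@H](CO)O[C@@H](n2ccc(N)nc2=O)[C@@H]1O`, keeps the shared core of compound 2 and changes one group: but-1-yn-1-yl in place of ethyl on a saturated ring carbon. Going by the values given here, there is no measured step on the same core against which the size of this change can be read. With both measured compounds at the limit, compound 3 is expected to stay near it as well, and the step of an at least 1.2-fold lower number from compound 2 to compound 3 (0.07 log units; that floor lies within the scatter) is an estimate of no change beyond the scatter. The estimate for compound 3 in this assay is 25000 nM, within 3000 nM to 100000 nM, with a sizeable chance that only a limit is reported.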

Compound 3, half-maximal inhibitory concentration: > 30000 nM
Compound 3 was reported as a limit; the forecaster's own chance of this, stated with the estimate: 65%; middle value at least 1.2-fold (0.07 log units) from the limit.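

In this assay compound 3 gives > 30000 nM, a limit of the assay. For the compounds shown here, compound 2 also stands at a limit, so no step from compound 2 to compound 3 can be read. The compounds shown leave open how but-1-yn-1-yl and ethyl on a saturated ring carbon compare, for all of them share one reading: the limit of > 30000 nM in this assay, at which 3 of the 3 values shown sit.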